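From (methylsulfonyl)carbamoyl to tetrazolyl on the ethenyl chain

A few compounds are considered here, and "the series" means these few. Any claim that something is new, unique, unknown or untested is made for them only; others in the source may bear on it.

In a physicochemical assay for lipophilicity, using the shake flask method (on this read-out higher numbers stand for higher lipophilicity and lower numbers for lower lipophilicity), compound 1 `C[C@H](Oc1ccc2ncc(/C=C/C(=O)NS(C)(=O)=O)c(C3CC3)c2c1)c1c(Cl)cccc1Cl` gives 2.9. This lies within the scatter of compound 2 `Cc1c(/C=C/C(=O)O)cnc2ccc(O[C@@H](C)c3c(Cl)ccc(F)c3Cl)cc12` at 3. Compound 3 `C[C@H](Oc1ccc2ncc(/C=C/C(=O)O)c(C#N)c2c1)c1c(Cl)ccc(F)c1Cl`, at 2.3, sits lower than compound 1, beyond the scatter.

Compound 4 `C[C@H](Oc1ccc2ncc(/C=C/c3nn[nH]n3)c(C3CC3)c2c1)c1c(Cl)cccc1Cl` keeps the core of compound 1 and changes one group: 2H-tetrazol-5-yl in place of (methylsulfonyl)carbamoyl on a double-bonded chain carbon bound to a double-bonded chain carbon. Thus 2H-tetrazol-5-yl stands in place of (methylsulfonyl)carbamoyl on a double-bonded chain carbon bound to a double-bonded chain carbon.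

Among the measured compounds shown here, no measured pair makes this exchange. The only measured step, a number 0.70 log units lower from compound 2 to compound 3 (beyond the scatter), is a different one, cyano in place of methyl on an aromatic carbon, so it offers only a rough sense of how far one exchange can move this assay among these compounds. The direction of the new step therefore remains uncertain. The expected step is a number 0.20 log units lower from compound 1 to compound 4 (within the scatter), a small downward move that is not expected to clear the scatter. Compound 4 is estimated at 2.7, with an expected range from 2.2 to 3.2.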

Compound 4, distribution coefficient: 4.3
Compound 4: the middle estimate sits 1.60 log units below what was measured; measured number above the stated range.
By their numbers in this assay, from the lowest: compound 3; then compounds 1 and 2 (each within the scatter of the next); then compound 4.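

In this assay, among the compounds shown here, the ethenyl chain proves a place where a single exchange can move the number a long way: 2H-tetrazol-5-yl in place of (methylsulfonyl)carbamoyl gives a number 1.40 log units higher from compound 1 to compound 4 (beyond the scatter) and this is larger than the one earlier step, a number 0.70 log units lower from compound 2 to compound 3 (beyond the scatter) and runs the other way. The two groups have the same counts of hydrogen-bond donors and hydrogen-bond acceptors and neither has a net charge, so these matching counts did not keep the read-out in place between the two compounds. Nothing measured here accounts for the size of this step.

The compounds shown leave open how a plain carboxylic acid would read on the core of compound 1, since compound 2 and compound 3 carry that group but differ from compound 1 in more than one place. On these data alone, it also remains open whether the same exchange would give a similar step on a core with methyl or nitrile in place of cyclopropyl.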